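Added hydroxy group on two related cores

The source may hold more compounds than are shown below. What is called first, only, known or untested is meant among the compounds shown, and "the series" means these compounds.

Compound 1 `Oc1cc2cc(c1O)Oc1ccc(cc1)CCc1cccc(O)c1Oc1cccc(c1)CC2` and compound 2 `Oc1ccc2cc1Oc1ccc(cc1)CCc1cccc(O)c1Oc1cccc(c1)CC2` share one core and differ by hydroxy in place of hydrogen on an aromatic carbon. In a functional assay on RAW264.7 cells (Mus musculus) for inhibition, read by Griess assay, with stated times of 1 h and 24 h (a higher number here means a weaker inhibitor, a lower number a stronger inhibitor), compound 2 gives 13300 nM, and compound 1 gives 1440 nM; the measured step is a 9.2-fold lower number from compound 2 to compound 1 (0.97 log units; beyond the scatter).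

Compound 3 `Oc1ccc2c(c1)CCc1ccc(O)c(c1)-c1cc(ccc1O)/C=C\c1cccc(c1)O2` is built on a second core; the difference between the two cores is not broken down here. In this assay compound 3 reaches only > 100000 nM, which is a limit of the assay and not a number, as shown by the limit of > 100000 nM in this assay, at which 1 of the 3 values shown sits.

Compound 4 `Oc1ccc2cc1-c1cc(ccc1O)CCc1c(ccc(O)c1O)Oc1cccc(c1)/C=C\2` has not yet been measured in this assay. It stands to compound 3 as compound 1 stands to compound 2, through (hydroxy in place of hydrogen on an aromatic carbon). The surroundings are not identical: in compound 1 the entering group is meta to two fused rings, whereas in compound 4 it is ortho to a fused ring and meta to a fused ring; in both it is ortho to a hydroxy group. The change is therefore the same kind of change, not the same.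

Within the data shown here, the expectation for compound 4 rests on the single measured instance, a 9.2-fold lower number from compound 2 to compound 1 (0.97 log units; beyond the scatter), applied to a starting point that is itself only a limit. For compound 4 a step of an at least 2.5-fold lower number from compound 3 to compound 4 (0.39 log units; beyond the scatter) is expected on that basis. Compound 4 is estimated at 40000 nM in this assay, with a likely range from 8000 nM to 150000 nM, and a real chance that only a limit is reported again.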

Compound 4, half-maximal inhibitory concentration: > 100000 nM
Compound 4 gave a limit, no number; the forecaster's own chance of this, stated with the estimate: 45%; middle value at least 2.5-fold (0.39 log units) from the limit.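

In this assay compound 4 gives > 100000 nM, a limit and not a number. Among these compounds, compound 3 also gives only a limit, so no step from compound 3 to compound 4 can be read: the limit of > 100000 nM in this assay, at which 2 of the 4 values shown sit. The compounds shown leave open whether hydroxy in place of hydrogen on an aromatic carbon shifts the value on the core of compound 3 in this assay at all.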